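The source may hold more compounds than are shown below. What is called first, only, known or untested is meant among the compounds shown, and "the series" means these compounds.

In an ADME assay on the whole organism with Oryza sativa as the target, tested at 10 uM (on this read-out higher numbers stand for a weaker effect at the one concentration tested and lower numbers for a stronger effect), compound 1 `CCc1ccc(NC(=O)N[C@@H](C)c2ccccc2)cc1` gives 91%. Compound 2 `CC(C)c1ccc(NC(=O)N[C@@H](C)c2ccccc2)cc1` gives 86%. Compound 3 `CCCCCc1ccc(NC(=O)N[C@@H](C)c2ccccc2)cc1` gives 93%.

All three compounds share one core and differ only in the group carried on the aromatic carbon at one end. Compound 3 sits close to both neighbours: a number 2 percentage points higher from compound 1 to compound 3 (within the scatter) and a number 7 percentage points higher from compound 2 to compound 3 (within the scatter), each within the scatter, as is a number 5 percentage points lower from compound 1 to compound 2 (within the scatter). So far the three numbers read as one level.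

Compound 4 `CCOC(=O)c1ccc(NC(=O)N[C@@H](C)c2ccccc2)cc1` takes the change (ethoxycarbonyl in place of pentyl on an aromatic carbon). Among the measured compounds shown here, the step that most resembles this in place is the one from compound 2 to compound 3, where one chain replaced another on the same aromatic carbon and gave a number 7 percentage points higher from compound 2 to compound 3 (within the scatter). For the measured compounds named here, no measured step, however, exchanges a chain for an ethoxycarbonyl group, so the three steps give only weak guidance. Going by the values given here, since every change at this position so far stayed within the scatter, compound 4 is expected to stay near compound 3 as well, with a step of about a number 5 percentage points lower from compound 3 to compound 4 (within the scatter), not beyond the scatter. The estimate for compound 4 is 88%, with a range from 70% to 100%.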

Compound 4, a percentage reported as activity, at one concentration (the size of the read-out at that concentration, not a potency): 92%
The estimate for compound 4 lay 4 percentage points below the measured number; the measured number falls inside the stated range.
By their numbers in this assay, from the lowest: compounds 2, 1, 4 and 3 (each within the scatter of the next).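

Putting ethoxycarbonyl in place of pentyl keeps the heavy-atom count but adds hydrogen-bond acceptors and a double bond outside the aromatic ring, and yet this assay stays at one level, with a number 1 percentage points lower from compound 3 to compound 4 (within the scatter). The comparisons with the other two chains agree, with a number 6 percentage points higher from compound 2 to compound 4 (within the scatter) and a number 1 percentage points higher from compound 1 to compound 4 (within the scatter), so on this aromatic carbon, para to a large group, the read-out does not separate ethoxycarbonyl from ethyl, isopropyl or pentyl. Nothing available offers an explanation for this level result.

All four groups give numbers within the scatter of one another, so the compounds shown do not tell whether any group at this position can shift the read-out. A carboxylic acid, an amine or a nitrile on the same aromatic carbon remains an open test.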